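This account rests on a few compounds, and the source may have more. Where it says the series, first, only, none or still open, it means among the compounds named here.

Measured compounds in an assay on CHO-K1 cells for displacement of a labelled ligand from prostaglandin E2 receptor EP1 subtype (Homo sapiens); on this read-out lower numbers stand for stronger inhibition and higher numbers for weaker inhibition:
- compound 1 `Cc1cc(C(=O)O)nn1Cc1cc(Br)ccc1OCc1ccc(Cl)cc1`, compound 1 gives 8.71 nM
- compound 2 `Cc1cc(C(=O)O)nn1Cc1cc(Br)ccc1OCc1ccccc1Cl`, compound 2 gives 3.16 nM

Compound 2 holds the lowest of the two numbers in this assay, and its nearest neighbour is compound 1, separated by a 2.8-fold lower number from compound 1 to compound 2 (0.44 log units; beyond the scatter). Compound 3 `Cc1cc(C(=O)O)nn1Cc1cc(Br)ccc1OCc1cccc(Br)c1` differs from compound 2 in one place: 3-bromophenyl in place of 2-chlorophenyl on a saturated chain carbon bound to an oxygen on an aromatic ring. Among the compounds with values here, the only measured step touching this position is the one from compound 1 to compound 2, which moved the chlorine on the same ring and gave a modest gain. Compound 3 carries a different halogen at a third position on that ring, so that step bears on it only loosely. A shift of roughly that size in either direction, or none beyond the scatter, seems possible. On balance compound 3 is expected to give about 5 nM in this assay, with a range from 1.6 nM to 16 nM, which as a step means an expected 1.6-fold higher number from compound 2 to compound 3 (0.20 log units; within the scatter).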

Compound 3, half-maximal inhibitory concentration: 17.8 nM
Beside the measured number, compound 3's estimate is 3.6-fold (0.55 log units) below it, outside the stated range (above it).
By their numbers in this assay, from the lowest: compound 2; then compound 1; then compound 3.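

In this assay, the 3-bromophenyl group on a saturated chain carbon bound to an oxygen on an aromatic ring gives a 5.6-fold higher number from compound 2 to compound 3 (0.75 log units; beyond the scatter) and, against the 4-chlorophenyl group, a 2.0-fold higher number from compound 1 to compound 3 (0.31 log units; beyond the scatter). Compound 3 therefore holds the highest number of the three, and the position responds to more than the shift of chlorine seen earlier, since both steps to the 3-bromophenyl compound lie beyond the scatter. No available information accounts for these differences. Both new steps change the halogen and its place on the ring together, so the contribution of each cannot be separated. From the compounds shown here alone, a 3-chlorophenyl group would bear directly on that question, and how a plain phenyl group compares with these three halogen-bearing rings remains open.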